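Cyclopropyl in Place of Fluoro on an Aromatic Carbon

A few compounds are considered here, and "the series" means these few. Any claim that something is new, unique, unknown or untested is made for them only; others in the source may bear on it.

Of the compounds shown here, three have been measured in an assay on Sf9 cells for inhibition of Amine oxidase [flavin-containing] B (Homo sapiens), with stated times of 15 min and 60 min; a lower number here means a stronger inhibitor, a higher number a weaker inhibitor. Compound 1 `Cc1cc(OCc2cccc(F)c2)ccc1CN[C@@H](C)C(N)=O` gives 69 nM, compound 2 `C[C@H](NCc1ccc(OCc2cccc(F)c2)cc1Cl)C(N)=O` gives 28 nM, and compound 3 `C[C@H](NCc1ccc(OCc2cccc(F)c2)cc1F)C(N)=O` gives 61 nM. Compound 3 thus holds the second highest of the three numbers: its value and that of compound 1 lie within the scatter of each other, whereas toward compound 2 the gap is a 2.2-fold higher number from compound 2 to compound 3 (0.34 log units; beyond the scatter), beyond the scatter.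

Compound 4 `C[C@H](NCc1ccc(OCc2cccc(F)c2)cc1C1CC1)C(N)=O` differs from compound 3 by cyclopropyl in place of fluoro on an aromatic carbon. Within the data shown here, two measured steps touch the same aromatic carbon. The exchange of methyl for fluoro gave a 1.1-fold lower number from compound 1 to compound 3 (0.05 log units; within the scatter), within the scatter, while the exchange of methyl for chloro gave a 2.5-fold lower number from compound 1 to compound 2 (0.39 log units; beyond the scatter), a modest change. Among the measured compounds shown here, every group tried at this carbon so far has given a number at or below that of compound 3, and none of them is a cyclopropyl, so no measured step covers the new group directly. A modest step toward a lower number, or none beyond the scatter, is therefore expected for compound 4 in this assay, and the estimate for compound 4 is 40 nM, with a range from 15 nM to 120 nM. This estimate for compound 4 corresponds to an expected step of a 1.5-fold lower number from compound 3 to compound 4 (0.18 log units; within the scatter).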

Compound 4, half-maximal inhibitory concentration: 1660 nM
Compound 4: middle estimate off by 42-fold (1.62 log units), on the low side; the measured number lies above the stated range.
By their numbers in this assay, from the lowest: compound 2; then compounds 3 and 1 (each within the scatter of the next); then compound 4.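

In this assay, among these compounds, the aromatic carbon ortho to the ((1-carbamoylethyl)amino)methyl group turns out to be far more sensitive to what it carries than the earlier compounds showed: cyclopropyl in place of fluoro gives a 27-fold higher number from compound 3 to compound 4 (1.43 log units; beyond the scatter), and the same group gives a 59-fold higher number from compound 2 to compound 4 (1.77 log units; beyond the scatter) against chloro and a 24-fold higher number from compound 1 to compound 4 (1.38 log units; beyond the scatter) against methyl. Among methyl, fluoro and chloro the largest step had been only a 2.5-fold lower number from compound 1 to compound 2 (0.39 log units; beyond the scatter), so the tolerance seen with those three groups does not extend to cyclopropyl, the only one of the four that brings a three-membered ring. Nothing available here bears on why the number rises so sharply with this group.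

The compounds shown leave open whether the loss follows the ring itself or the count of carbons, a question that an ethyl or an isopropyl group on the same carbon could separate. They also leave open how bromo, methoxy or trifluoromethyl would fare there, and so where between chloro and cyclopropyl the steep rise in the number begins.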